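Closing the amide into a ring on the shared biaryl scaffold

A few compounds are considered here, and "the series" means these few. Any claim that something is new, unique, unknown or untested is made for them only; others in the source may bear on it.

Of the compounds shown here, three have been measured in a functional assay on cells for agonist activity at Glucose-dependent insulinotropic receptor (Homo sapiens), read by a luciferase reporter, with a stated time of 6 h; a lower number here means that less compound is needed, a higher number that more compound is needed for the effect. Compound 1 `CON(C)C(=O)c1ccc(-c2csc3c(OC4CCN(C(=O)OC(C)(C)C)CC4)ncnc23)cc1F` gives 57 nM. For the measured compounds named here, compound 2 `CCc1cnc(N2CCC(Oc3ncnc4c(-c5ccc(C(=O)N(C)OC)c(F)c5)csc34)CC2)nc1` gives 105 nM, and the only single-point step among them, a 1.8-fold higher number from compound 1 to compound 2 (0.27 log units; within the scatter), concerns the amine nitrogen in a ring rather than the amide end of the molecule. Compound 3 `CON(C)C(=O)c1ccc(-c2ccc(OCC3CCN(C(=O)OC(C)(C)C)CC3)cn2)cc1` gives 171 nM; its number is the highest of the three, within the scatter of compound 2 and beyond the scatter of compound 1, from which it differs in more than one place.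

Compound 4 `CC(C)(C)OC(=O)N1CCC(COc2ccc(-c3ccc(C(=O)N4CCCCO4)cc3)nc2)CC1` is the unmeasured compound. It differs from compound 3 by a group of 6 heavy atoms (4 carbon, 1 nitrogen, 1 oxygen; one six-membered non-aromatic ring with 2 hetero atoms) in place of a group of 4 heavy atoms (2 carbon, 1 nitrogen, 1 oxygen; no ring), on a carbonyl carbon. Going by the values given here, no measured step touches this carbonyl carbon; the one step seen, from compound 1 to compound 2, sits on a different part of the molecule and was itself within the scatter. The expectation for compound 4 therefore rests on the unchanged remainder of compound 3 alone, so the step of a 1.2-fold higher number from compound 3 to compound 4 (0.07 log units; within the scatter) is expected to stay within the scatter, with no clear direction. Compound 4 is thus estimated at 200 nM, in a range from 70 nM to 600 nM.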

Compound 4, half-maximal effective concentration: 321 nM
For compound 4 the middle estimate is 1.6-fold (0.21 log units) below the measured one; low and high end bracket the measured number.
By their numbers in this assay, from the lowest: compounds 1, 2, 3 and 4 (each within the scatter of the next, the first and the last beyond it).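

For the compounds shown here, this is the first measured change on the carbonyl carbon: in this assay, putting a six-membered non-aromatic ring with 2 hetero atoms in place of methoxy(methyl)amino gives a 1.9-fold higher number from compound 3 to compound 4 (0.27 log units; within the scatter), so on this scaffold the amide can be closed into a ring without a step beyond the scatter. The two groups have the same counts of hydrogen-bond donors and acceptors and no net charge, but the entering group has a ring and more heavy atoms, and this single pair cannot separate the effect of the ring from that of the added atoms. Nothing available offers an explanation for the size of this step or bears on the result.

Going by these compounds alone, how a dimethylamino group or a morpholine ring would compare on this carbonyl carbon stays open, since the only change seen here is from one group to one other. Within the data shown here, it is also open whether the same ring would give a similar step on the core of compound 1 or with 5-ethylpyrimidin-2-yl on the amine nitrogen, as in compound 2, because the change has been seen only with the remainder of compound 3.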